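The source may report more compounds than this note shows. Statements on the series, on what has been measured and on what is new or still open speak of the compounds shown alone.

Measured compounds:
compound 1, `O=S(=O)(CC1=NCCO1)c1n[nH]cc1-c1ccc(Cl)cc1`, "not active" (no number reported);
compound 2, `O=S(=O)(CC1=NCCS1)c1n[nH]cc1-c1ccc(Cl)cc1`, "not active" (no number reported);
compound 3, `COc1ccc(C2=NOC(c3ccc(C)cc3)C2S(=O)(=O)CC2=NCCS2)cc1`, 49.7%.

All three compounds were tested in a functional assay, tested at 75 ug/mL; on this read-out higher numbers stand for a stronger effect at the one concentration tested and lower numbers for a weaker effect. Compound 1 gives "not active" (no number reported), so no number stands for it, only the statement that the assay saw no effect. Compound 2 gives "not active" (no number reported) as well, the second entry without a number. Going by the values given here, compound 3, built on a different core, is the only one with a figure, 49.7%; no step between compound 3 and either of the others is set out, so the two kinds of result can only be placed side by side, not compared as a change.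

Compound 4, `Cc1ccc(-c2c[nH]nc2S(=O)(=O)CC2=NCCO2)cc1`, has not yet been measured. It differs from compound 1 in one place: methyl in place of chloro on an aromatic carbon. With methyl in place of chloro on an aromatic carbon the rest of compound 1 is kept. Among the compounds with values here, since compound 1 gives "not active" (no number reported), there is no number from which a step could be counted, and no pair of measured compounds shows what such a swap does in this assay. Compound 4 is expected to give 10%, within a range from 0% to 35%, most likely again with no effect reported.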

Compound 4, a percentage reported as activity, at one concentration (the size of the read-out at that concentration, not a potency): 62%
For compound 4 the middle estimate is 52 percentage points below the measured one; measured number outside the range, above it.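

Going by these compounds alone, no step can be counted between compound 1 and compound 4: in this assay compound 1 gives "not active" (no number reported) and compound 4 gives 62% as a figure, so only one of the pair has a number. No supporting measurement bears on this result. The compounds shown leave open how far 4-chlorophenyl to 4-methylphenyl would shift the read-out on other cores.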